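This account rests on a few compounds, and the source may have more. Where it says the series, first, only, none or still open, it means among the compounds named here.

Measured so far in the series:

- compound 1 `COC(=O)c1cccc(C(=O)N2CCCC(C(=O)Nc3ccc(Cl)cc3)C2)c1`: 0%
- compound 2 `CC(=O)Nc1cccc(C(=O)N2CCCC(C(=O)Nc3ccc(Cl)cc3)C2)c1`: 4%
- compound 3 `C=Cc1cccc(C(=O)N2CCCC(C(=O)Nc3ccc(Cl)cc3)C2)c1`: 0%

All three were run in an ADME assay on PC-3 cells (Homo sapiens) for cytotoxicity, read by WST assay, tested at 100 uM; a lower number here means less inhibition, a higher number more inhibition at the concentration tested (going by the name of the read-out). Compound 3 stands level with compound 1 at the digits printed, the two of them together the lowest of the three numbers; the nearest neighbour is compound 1, with no change at the digits printed from compound 1 to compound 3 (within the scatter), and the furthest is compound 2, with a number 4 percentage points lower from compound 2 to compound 3 (within the scatter). The third step, a number 4 percentage points higher from compound 1 to compound 2 (within the scatter), is likewise within the scatter, so across the three compounds nothing moves beyond the noise of the measurement.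

The next compound, compound 4 `Cc1nc(-c2cccc(C(=O)N3CCCC(C(=O)Nc4ccc(Cl)cc4)C3)c2)cs1`, has not been measured. Its change from compound 3 is 2-methyl-1,3-thiazol-4-yl in place of vinyl on an aromatic carbon, a substitution at the same aromatic carbon that is varied in every measured step. Those three steps are the ones that bear on it: each exchanged the group on that carbon, and each stayed within the scatter. On that basis the expected step of a number 3 percentage points higher from compound 3 to compound 4 (within the scatter) is none beyond the scatter, with no direction favoured. For compound 4 the estimate in this assay is therefore 3%, with a range from 0% to 15%.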

Compound 4, a percentage reported as inhibition, at one concentration (the size of the read-out at that concentration, not a potency): 1%
For compound 4 the middle estimate is 2 percentage points above the measured one; the measured number falls inside the stated range.
By their numbers in this assay, from the lowest: compounds 1, 3, 4 and 2 (each within the scatter of the next).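

In this assay, going by these compounds alone, the 2-methyl-1,3-thiazol-4-yl group puts a five-membered aromatic ring on this aromatic carbon, something none of the earlier groups did, and the exchange for vinyl gives a number 1 percentage points higher from compound 3 to compound 4 (within the scatter) with no departure from the earlier compounds. The comparisons with the other two groups read the same way: the exchange for acetamido gives a number 3 percentage points lower from compound 2 to compound 4 (within the scatter) and the exchange for methoxycarbonyl gives a number 1 percentage points higher from compound 1 to compound 4 (within the scatter) on the same carbon. The flat picture at this position, at the single concentration tested, therefore now extends from the two-carbon vinyl group to a ring-bearing group of six heavy atoms, with all the new steps within the scatter.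

Still open, from the compounds shown here alone, is whether any group on this carbon moves the number beyond the scatter, for example a carboxylic acid, a primary amine or a longer alkyl chain. Also open, going by these compounds, is whether a change elsewhere on the shared core, such as replacing the chlorine with a methoxy group, would do so.

No measurement shown offers an explanation for this result.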